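This account rests on a few compounds, and the source may have more. Where it says the series, first, only, none or still open, it means among the compounds named here.

Measured compounds in a functional assay on SMMC-7721 cells (Homo sapiens) for cytotoxicity, read by MTT assay, with a stated time of 24 h; a lower number here means a stronger inhibitor, a higher number a weaker inhibitor:
- compound 1, `O=C1/C(=C/c2cccnc2)CN(S(=O)(=O)c2ccc(F)cc2)C/C1=C\c1ccccc1F`: 9900 nM
- compound 2, `O=C1/C(=C/c2cccnc2)CN(S(=O)(=O)c2ccc(Cl)cc2)C/C1=C\c1ccccc1F`: 16100 nM
- compound 3, `O=C1/C(=C/c2ccncc2)CN(S(=O)(=O)c2ccc(F)cc2)C/C1=C\c1ccccc1C(F)(F)F`: 9270 nM

Compounds 1 and 2 share a core and differ by one change, (chloro in place of fluoro on an aromatic carbon). That change gave a 1.6-fold higher number from compound 1 to compound 2 (0.21 log units; within the scatter), so the two values sit within the scatter of one another and no order between compound 1 and compound 2 can be read from them.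

Compound 3 carries a different core; the difference between the core of compound 1 and the core of compound 3 is not broken down here. Its value in this assay sits within the scatter of both compound 1 and compound 2.

Compound 4, `O=C1/C(=C/c2ccncc2)CN(S(=O)(=O)c2ccc(Cl)cc2)C/C1=C\c1ccccc1C(F)(F)F`, is not yet measured. It differs from compound 3 by chloro in place of fluoro on an aromatic carbon, the same change as from compound 1 to compound 2. For compound 4 a step of about a 1.4-fold higher number from compound 3 to compound 4 (0.15 log units; within the scatter) is expected, resting on the step seen from compound 1 to compound 2, a 1.6-fold higher number from compound 1 to compound 2 (0.21 log units; within the scatter), which stayed within the scatter. Compound 4 is thus estimated at 13000 nM in this assay, with an expected range from 7000 nM to 26000 nM.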

Compound 4, half-maximal inhibitory concentration: 5510 nM
Estimate against measurement, compound 4: 2.4-fold (0.37 log units) above; the whole stated range lies above it.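

In this assay, chloro in place of fluoro on the arylsulfonyl ring gives a 1.7-fold lower number from compound 3 to compound 4 (0.23 log units; within the scatter), so no order between the two compounds can be read from their values. Set beside the earlier step, the change does not carry over as one fixed increment from the core of compound 1 to the core of compound 3: the same change on two cores in this assay, a 1.6-fold higher number (0.21 log units; within the scatter) from compound 1 to compound 2 and a 1.7-fold lower number (0.23 log units; within the scatter) from compound 3 to compound 4, 2.7-fold (0.44 log units) apart, beyond the scatter of two such steps Neither step alone departs from the scatter, so the pairs show no firm effect of the change on either core, and two cores cannot show which part of the difference between them goes with the gap or whether it would recur elsewhere in the series.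

The compounds shown leave open how a third core would respond to the same change, which would test whether the gap persists. They also leave open how a group other than a halogen would fare in that place on the ring, such as an amine, a carboxylic acid or a methoxy group.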